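The source may report more compounds than this note shows. Statements on the series, on what has been measured and on what is new or still open speak of the compounds shown alone.

Within the data shown here, in a functional assay on HepG2 cells (Homo sapiens) for antiproliferative activity, read by MTT assay, with a stated time of 24 h (a higher number here means a weaker inhibitor, a lower number a stronger inhibitor), compound 3 (`COc1cc(OC)c(-c2coc3cc(OCc4cccc(F)c4)ccc3c2=O)cc1OC`) gives 1230 nM, the only exact number so far. Compound 1 (`COc1cccc(C(=O)Oc2ccc3c(=O)c(-c4cc(OC)c(OC)cc4OC)coc3c2)c1`) reads > 10000 nM, which is a limit and not a number. Compound 2 (`COc1cc(OC)c(-c2coc3cc(OCC(=O)c4cccc(C(F)(F)F)c4)ccc3c2=O)cc1OC`) reads > 10000 nM, also a limit. Among the measured compounds shown here, two measured steps bear on what follows: an at least 8.1-fold lower number from compound 1 to compound 3 (0.91 log units; beyond the scatter), and an at least 8.1-fold lower number from compound 2 to compound 3 (0.91 log units; beyond the scatter). As far as these compounds go, both start from the limit of > 10000 nM in this assay, at which 2 of the 3 values shown sit, so their full size remains unknown. Compound 4 (`COc1cc(OC)c(-c2coc3cc(OCc4ccccc4Cl)ccc3c2=O)cc1OC`) has 2-chlorophenyl in place of 3-fluorophenyl on a saturated chain carbon bound to an oxygen on an aromatic ring. For the measured compounds named here, both measured steps removed a carbonyl, while this change does not, and no measured step exchanges fluorine for chlorine. In this assay, the expected result is no change beyond the scatter: a 1.2-fold higher number from compound 3 to compound 4 (0.09 log units; within the scatter). The estimated value for compound 4 is 1500 nM, with an expected range from 500 nM to 5000 nM.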

Compound 4, half-maximal inhibitory concentration: 1690 nM
For compound 4 the middle estimate is 1.1-fold (0.05 log units) below the measured one; the range from low to high includes it.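

In this assay, 2-chlorophenyl in place of 3-fluorophenyl gives a 1.4-fold higher number from compound 3 to compound 4 (0.14 log units; within the scatter), so the two groups cannot be told apart at this place. The second compound without a carbonyl also stands clear of the two compounds that carry one, with an at least 5.9-fold lower number from compound 2 to compound 4 (0.77 log units; beyond the scatter) and an at least 5.9-fold lower number from compound 1 to compound 4 (0.77 log units; beyond the scatter). Both of these steps start from a limit, so their full size stays unknown: the limit of > 10000 nM in this assay, at which 2 of the 4 values shown sit.

As far as these compounds go, whether plain benzyl, with no halogen, would read the same stays open. So does the effect of an amine or a carboxylic acid on the ring, or of a longer chain on the oxygen.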